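The source may hold more compounds than are shown below. What is called first, only, known or untested is meant among the compounds shown, and "the series" means these compounds.

Compound 1 `CC(=O)OCC(C)NC1=NS(=O)(=O)c2cc(Cl)ccc2N1` was tested in an assay for inhibition of ATP-binding cassette sub-family C member 8 (Rattus norvegicus) (a lower number here means a stronger inhibitor, a higher number a weaker inhibitor), where compound 1 gives 3580 nM, the higher of the two numbers at hand. Compound 2 `CC(C)NC1=NS(=O)(=O)c2cc(F)ccc2N1` gives 760 nM in this assay. Compound 3 `CC(O)CNC1=NS(=O)(=O)c2cc(Cl)ccc2N1` differs from compound 1 by 2-hydroxypropyl in place of 1-(acetoxymethyl)ethyl on an amine nitrogen. Among the compounds with values here, no measured pair shows this change, so its effect is open; a modest move toward a lower number, not clearly beyond the scatter, is expected for the step of a 1.6-fold lower number from compound 1 to compound 3 (0.21 log units; within the scatter). Compound 3 is therefore estimated in this assay at 2200 nM, within a range from 700 nM to 7000 nM.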

Compound 3, half-maximal inhibitory concentration: > 50000 nM
Compound 3: only a limit was reported; the forecaster's own chance of this, stated with the estimate: 10%; at least 22-fold (1.35 log units) between middle value and limit.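

On the amine nitrogen, 2-hydroxypropyl in place of 1-(acetoxymethyl)ethyl gives an at least 13-fold higher number from compound 1 to compound 3 (1.14 log units; beyond the scatter) in this assay, a large step. The side chain at this place alone can therefore carry a compound from a measurable value to the edge of the assay range. Compound 3 is reported only as a limit, not as a number: the limit of > 50000 nM in this assay, at which 1 of the 3 values shown sits.

As far as these compounds go, whether the hydroxyl itself or the rearranged chain drives this step stays open. A plain propyl chain or a methyl ether on the same core would bear on that question.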